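From chloro to methoxy on the shared core

The source may hold more compounds than are shown below. What is called first, only, known or untested is meant among the compounds shown, and "the series" means these compounds.

Compound 1: `Cc1cc(NC(=O)Nc2ccc(F)cc2)c2ccccc2n1`, > 25000 nM
Compound 2: `Cc1cc(NC(=O)Nc2ccc(Cl)cc2)c2ccccc2n1`, > 25000 nM

In an ADME assay on HEK293 cells (Homo sapiens) for cytotoxicity, with a stated time of 72 h (on this read-out lower numbers stand for an effect already at smaller amounts and higher numbers for an effect only at larger amounts of compound), compound 2 gives > 25000 nM, which is a limit and not a number. Compound 1 gives > 25000 nM, which is also a limit. The measurements so far therefore offer only (the limit of > 25000 nM in this assay, at which 2 of the 2 values shown sit).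

Compound 3, `COc1ccc(NC(=O)Nc2cc(C)nc3ccccc23)cc1`, differs from compound 2 by one exchange, methoxy in place of chloro on an aromatic carbon. Going by the values given here, the only measured step, a step that the two limits leave unreadable from compound 1 to compound 2, is also an exchange on an aromatic carbon, but it gives no size to carry over. No shift beyond the scatter is therefore expected in this assay, and no direction can be assigned. The estimated step is a number no higher from compound 2 to compound 3 (the limit leaves the size open). Compound 3 is expected at 25000 nM, with an estimated range of 12000 nM to 50000 nM.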

Compound 3, half-maximal effective concentration: > 25000 nM
Compound 3 ended at the assay's limit; the forecaster's own chance of this, stated with the estimate: 85%; the middle value sits exactly at the limit.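

In this assay compound 3 gives > 25000 nM as a limit and not a number, so its steps from compound 1 and compound 2 cannot be read: the limit of > 25000 nM in this assay, at which 3 of the 3 values shown sit. The compounds shown leave open whether fluoro, chloro and methoxy on the shared core differ at all on this read-out.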